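A few compounds are considered here, and "the series" means these few. Any claim that something is new, unique, unknown or untested is made for them only; others in the source may bear on it.

Compound 2 `COc1ccc(CNC(=O)/C(C#N)=C/c2ccc3ccccc3c2)cc1` was examined in a functional assay on NCI-H460 cells (Homo sapiens) for inhibition, read by MTT assay, with a stated time of 72 h; a higher number here means a weaker inhibitor of growth, a lower number a stronger inhibitor of growth. In this assay compound 2 gives > 100000 nM, which is a limit of the assay rather than a number. Compound 1 `N#C/C(=C\c1ccc[nH]1)C(=O)NCc1ccc(Cl)c(Cl)c1` shares the nitrile-bearing amide framework of compound 2. In this assay compound 1 gives > 50000 nM, again a limit and not a number. Compound 2 thus stands at one of the two limits recorded here, the one given in the limit of > 100000 nM in this assay, at which 1 of the 2 values shown sits, while compound 1 sits at the other, given in the limit of > 50000 nM in this assay, at which 1 of the 2 values shown sits. Neither value supplies a number from which a measured step could be drawn.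

Compound 3 `N#C/C(=C\c1ccc2ccccc2c1)C(=O)NCc1ccc(Cl)c(Cl)c1` differs from compound 2 by 3,4-dichlorophenyl in place of 4-methoxyphenyl on a saturated chain carbon bound to an amide-type nitrogen. Going by the values given here, no measured step covers that exchange, and both measured compounds sit at limits, so no direction can be read from them. The step from compound 2 to compound 3 is expected to be an at least 1.2-fold lower number from compound 2 to compound 3 (0.09 log units; that floor lies within the scatter), that is, nothing resolvable beyond the scatter. Compound 3 is accordingly estimated at 80000 nM, with a range from 15000 nM to 300000 nM, and the outcome is expected more often to be a limit than a number.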

Compound 3, concentration for 50% growth inhibition: > 100000 nM
Compound 3 ended at the assay's limit (the forecaster's own chance of this, stated with the estimate: 70%); middle value at least 1.2-fold (0.09 log units) from the limit.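

Compound 3 ends at the same limit as compound 2, which is a limit and not a number: the limit of > 100000 nM in this assay, at which 2 of the 3 values shown sit. No step can be read from compound 2 to compound 3. The compounds shown leave open whether 3,4-dichlorophenyl in place of 4-methoxyphenyl changes the result in this assay, and whether any of them would reach a measurable number there.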